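Methoxy addition in the acetyl branch of the series

The compounds below may be only part of what the source reports. "The series", "measured", "known", "first", "only" and "open" are said of these compounds alone.

Among the measured compounds shown here, compound 2, `C=C(C)[C@@H]1CC=C(Cn2cc(COc3cccc(C4NC(=O)NC(C)=C4C(C)=O)c3)nn2)CC1`, holds the only number at hand: in a functional assay on PC-3 cells (Homo sapiens) for inhibition, read by sulforhodamine B assay, with a stated time of 48 h (a lower number here means a stronger inhibitor of growth, a higher number a weaker inhibitor of growth), compound 2 gives 49800 nM. Compound 1, `C=C(C)[C@@H]1CC=C(Cn2cc(COc3cc(C4NC(=O)NC(C)=C4C(=O)OCC)ccc3OC)nn2)CC1`, reaches only a limit of this assay, > 100000 nM. Compound 3, `C=C(C)[C@@H]1CC=C(Cn2cc(COc3cc(C4NC(=O)NC(C)=C4C(C)=O)ccc3OC)nn2)CC1`, differs from compound 2 by methoxy in place of hydrogen on an aromatic carbon. For the measured compounds named here, no step between measured compounds exists; compound 1, which also carries methoxy, sits at the limit of > 100000 nM in this assay, at which 1 of the 2 values shown sits, so the step expected from compound 2 to compound 3 is a weakening beyond the scatter, a 1.8-fold higher number from compound 2 to compound 3 (0.26 log units; within the scatter), though compound 1 differs from compound 3 elsewhere too. Compound 3 is estimated at 90000 nM, between 35000 nM and 250000 nM.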

Compound 3, concentration for total growth inhibition: > 100000 nM
Compound 3: a limit, no number; the forecaster's own chance of this, stated with the estimate: 45%; at least 1.1-fold (0.04 log units) between middle value and limit.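

Methoxy in place of hydrogen on this aromatic carbon, ortho to a large group and para to a large group, now has a direct step in this assay: an at least 2.0-fold higher number from compound 2 to compound 3 (0.30 log units; that floor lies within the scatter). Compound 3 gives a limit, not a number, so this step is only a floor and does not establish a loss beyond the scatter. Methyl in place of ethoxy on the carbonyl carbon cannot be read from two limits, and both methoxy compounds share the same ceiling: the limit of > 100000 nM in this assay, at which 2 of the 3 values shown sit.

Going by these compounds, how far the methoxy step runs past its floor remains open. Also open, on these data alone, is whether a hydroxyl or a fluorine on this carbon would give a measurable number, as compound 2 does.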